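Swapping a benzylamine link for a thioether

The source may hold more compounds than are shown below. What is called first, only, known or untested is meant among the compounds shown, and "the series" means these compounds.

Compound 1 `Nc1cc(N)c2nc(-c3ccccc3)c(NCc3ccc(Cl)c(Cl)c3)nc2c1`: in a functional assay on UACC-62 cells (Homo sapiens) for inhibition, read by sulforhodamine B assay, with a stated time of 48 h (a higher number here means that more compound is tolerated, a lower number that less compound is tolerated), compound 1 gives 67600 nM.
Compound 2 `Nc1cc(N)c2nc(-c3ccccc3)c(NCc3ccc(F)cc3)nc2c1`: in this assay compound 2 gives 56200 nM.
Compound 3 `COc1ccc(CNc2nc3cc(N)cc(N)c3nc2-c2ccccc2)cc1`: in this assay compound 3 gives 58900 nM.

All three share one core and differ only in the group carried on the saturated chain carbon bound to the ring nitrogen. Compound 2 sits among them with both of its measured steps inside the scatter: a 1.2-fold lower number from compound 1 to compound 2 (0.08 log units; within the scatter) and a 1.0-fold higher number from compound 2 to compound 3 (0.02 log units; within the scatter). The third step, a 1.1-fold lower number from compound 1 to compound 3 (0.06 log units; within the scatter), is likewise within the scatter, so the three measured numbers cannot be told apart.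

Compound 4 `Nc1cc(N)c2nc(-c3ccccc3)c(Sc3ccc(F)cc3)nc2c1` takes a different kind of change: (4-fluorophenyl)sulfanyl in place of (4-fluorobenzyl)amino on an aromatic carbon. Going by the values given here, none of the measured steps bears on this. Each of them only exchanged the group on the outer phenyl ring while the benzylamino link stayed in place. The new link in compound 4 is therefore untested, and the measured steps give no direction to expect.

With no guide beyond the shared core, compound 4 is estimated at 56000 nM in this assay, with a range from 18000 nM to 170000 nM. That estimate amounts to an expected 1.0-fold lower number from compound 2 to compound 4 (0.00 log units; within the scatter), a step that may fall either way.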

Compound 4, concentration lethal to 50% of the cells: 60300 nM
Beside the measured number, compound 4's estimate is 1.1-fold (0.03 log units) below it; the measured number falls inside the stated range.
By their numbers in this assay, from the lowest: compounds 2, 3, 4 and 1 (each within the scatter of the next).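

The earlier compounds shown here changed only the group on the outer phenyl ring, while this change replaces the link itself: the (4-fluorobenzyl)amino group, which carries a hydrogen-bond donor, leaves, and the (4-fluorophenyl)sulfanyl group, which carries none, enters. In this assay the result is a 1.1-fold higher number from compound 2 to compound 4 (0.03 log units; within the scatter), so at this position, on an aromatic carbon next to the ring nitrogen and ortho to a phenyl group, exchanging the nitrogen-and-carbon link for a sulfur link gives a number that cannot be told apart from the earlier one, even with the donor gone. No supporting measurement is available to explain this outcome.

Still open, on these data alone, is whether any other link at this position would give a number beyond the scatter, such as an ether oxygen or a longer chain like a (4-fluorophenethyl)amino group, or whether a simple amine or a carboxylic acid in place of the whole group would do so. The sulfur link also remains to be read with other outer rings, such as the 3,4-dichlorophenyl or 4-methoxyphenyl groups.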